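This account rests on a few compounds, and the source may have more. Where it says the series, first, only, none or still open, it means among the compounds named here.

In a functional assay on SMMC-7721 cells (Homo sapiens) for antiproliferative activity, read by MTT assay, with a stated time of 48 h (a higher number here means a weaker inhibitor, a lower number a stronger inhibitor), compound 1 `CN1CCN(CCCn2nc(C3=C(c4cn(C)c5ccccc45)C(=O)NC3=O)c3cccnc32)CC1` gives only a limit of the assay, > 100000 nM. Compound 2 `Cn1cc(C2=C(c3nn(CCCn4ccnc4)c4ncccc34)C(=O)NC2=O)c2ccccc21` likewise reaches only a limit in this assay, > 100000 nM. Where compound 2 stands on the numbers shown is therefore a limit and nothing more; across the two values recorded the picture is uniform: the limit of > 100000 nM in this assay, at which 2 of the 2 values shown sit. The step that the two limits leave unreadable from compound 1 to compound 2 adds nothing readable for the same reason. The next step leads to compound 3 `Cn1cc(C2=C(c3nn(CCCn4cncn4)c4ncccc34)C(=O)NC2=O)c2ccccc21`, which differs from compound 2 by 1H-1,2,4-triazol-1-yl in place of 1H-imidazol-1-yl on a saturated chain carbon, three bonds along the chain from an aromatic nitrogen. For the measured compounds named here, the only measured step that touches this position is the one just described, and its size cannot be read; no measured step at all separates a 1H-imidazol-1-yl group from a 1H-1,2,4-triazol-1-yl group. Compound 3 is therefore expected to give a limit once more in this assay, with the step that the limit leaves unreadable from compound 2 to compound 3 amounting to no change that the numbers could register. The half-maximal inhibitory concentration of compound 3 is estimated at 150000 nM, within a range from 50000 nM to 500000 nM.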

Compound 3, half-maximal inhibitory concentration: > 100000 nM
Compound 3: a limit, no number (the forecaster's own chance of this, stated with the estimate: 85%); the middle value is on the limit's open side.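

Compound 3 gives only a limit in this assay, so no step among compound 1, compound 2 and compound 3 can be read: the limit of > 100000 nM in this assay, at which 3 of the 3 values shown sit.

The compounds shown leave open whether the 4-methylpiperazin-1-yl, 1H-imidazol-1-yl and 1H-1,2,4-triazol-1-yl groups differ at all in this assay, and which change to the shared core would give a readable value.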